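The compounds below may be only part of what the source reports. "The series", "measured", "known", "first", "only" and "open" are said of these compounds alone.

Three compounds share one core and differ only in the ring attached to the carbonyl carbon of the amide. Compound 3 `O=C(Nc1cccc(-c2oc3cc(-c4ccc(F)cc4)ccc3c(=O)c2O)c1)c1cccc(F)c1` carries a 3-fluorophenyl there; in a functional assay on HepG2 cells (Homo sapiens) for antiproliferative activity, read by CCK-8 assay, with a stated time of 72 h (a lower number here means a stronger inhibitor, a higher number a weaker inhibitor), compound 3 gives 15500 nM, the highest of the three numbers, although its gaps to the other two are within the scatter. Compound 1 `O=C(Nc1cccc(-c2oc3cc(-c4ccc(F)cc4)ccc3c(=O)c2O)c1)c1ccccc1F` gives 10100 nM in this assay, and compound 2 `COc1ccc(C(=O)Nc2cccc(-c3oc4cc(-c5ccc(F)cc5)ccc4c(=O)c3O)c2)cc1` gives 8420 nM. Compound 4 `COc1ccc(C(=O)Nc2cccc(-c3oc4cc(-c5ccc(F)cc5)ccc4c(=O)c3O)c2)c(F)c1` joins both of their features: 2-fluoro-4-methoxyphenyl in place of 3-fluorophenyl on a carbonyl carbon. Among the measured compounds shown here, the steps that bear on this are small: a 1.5-fold higher number from compound 1 to compound 3 (0.19 log units; within the scatter) and a 1.8-fold higher number from compound 2 to compound 3 (0.27 log units; within the scatter). Nothing here points beyond the scatter. Compound 4 is therefore expected to give 9500 nM in this assay, between 4500 nM and 20000 nM, an estimated step of a 1.6-fold lower number from compound 3 to compound 4 (0.21 log units; within the scatter).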

Compound 4, half-maximal inhibitory concentration: 45300 nM
The estimate for compound 4 lay 4.8-fold (0.68 log units) below the measured number, and the stated range ends below it.
By their numbers in this assay, from the lowest: compounds 2, 1 and 3 (each within the scatter of the next); then compound 4.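

Fluoro in place of hydrogen (a 5.4-fold higher number from compound 2 to compound 4 (0.73 log units; beyond the scatter)) and methoxy in place of hydrogen (a 4.5-fold higher number from compound 1 to compound 4 (0.65 log units; beyond the scatter)) each raise the number in this assay once the other group is already on the ring. The two groups therefore do not act independently here: the rings carrying one group sit within the scatter of each other, while 2-fluoro-4-methoxyphenyl stands apart, also from 3-fluorophenyl (a 2.9-fold higher number from compound 3 to compound 4 (0.47 log units; beyond the scatter)). No measurement shown explains this rise. Still open, as far as these compounds go, is whether chloro in place of the fluoro, or an amine in place of the methoxy, would give the same rise.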